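Removing the indole-ring methoxy: compound 3 to compound 4

A few compounds are considered here, and "the series" means these few. Any claim that something is new, unique, unknown or untested is made for them only; others in the source may bear on it.

Measured in a functional assay on NCI-H226 cells (Homo sapiens) for inhibition, read by sulforhodamine B assay, with a stated time of 48 h; on this read-out lower numbers stand for stronger inhibition of growth and higher numbers for weaker inhibition of growth:
compound 1 `COc1ccc(-c2[nH]c3ccccc3c2/C=C(\C#N)S(=O)(=O)c2ccccc2)cc1` gives 2800 nM
compound 2 `CC(=O)/C(=C\c1c(-c2ccccc2)[nH]c2ccccc12)S(=O)(=O)c1ccccc1` gives 1900 nM
compound 3 `COc1ccc2[nH]c(-c3ccccc3)c(/C=C(\C#N)S(=O)(=O)c3ccccc3)c2c1` gives 9400 nM

Compound 3 stands at the highest of the three numbers, that is, the weakest growth inhibition. Compound 1 sits at a lower number and compound 2 at a lower number still, and both gaps from compound 3 lie beyond the scatter. Going by the values given here, compounds 1 and 2 differ from compound 3 in more than one place each, so no single structural step between measured compounds is available.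

Compound 4 `N#C/C(=C\c1c(-c2ccccc2)[nH]c2ccccc12)S(=O)(=O)c1ccccc1` differs from compound 3 in one place: hydrogen in place of methoxy on an aromatic carbon. Compound 4 is thus the unsubstituted parent of the series. The other two measured compounds also lack a methoxy on this ring, and because compound 2 gives 1900 nM and compound 1 gives 2800 nM, the number for compound 4 is expected to fall below that of compound 3, though the other differences in those two compounds leave this uncertain. The expected step of a 3.1-fold lower number from compound 3 to compound 4 (0.50 log units; beyond the scatter) is a lowering beyond the scatter. For compound 4 the estimate in this assay is 3000 nM, with a range from 1200 nM to 8000 nM.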

Compound 4, concentration for 50% growth inhibition: 4100 nM
For compound 4 the middle estimate is 1.4-fold (0.14 log units) below the measured one; measured number inside the range.
By their numbers in this assay, from the lowest: compounds 2, 1 and 4 (each within the scatter of the next, the first and the last beyond it); then compound 3.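

In this assay, going by these compounds alone, hydrogen in place of methoxy on this aromatic carbon of the fused two-ring system gives a 2.3-fold lower number from compound 3 to compound 4 (0.36 log units; beyond the scatter), a modest step beyond the scatter and the first single-change reading at this position, which ties the methoxy here to weaker growth inhibition. The same exchange on a different aromatic carbon gives a 1.5-fold higher number from compound 1 to compound 4 (0.17 log units; within the scatter), within the scatter, so the two methoxy placements do not read alike in this pair of steps. On the double-bonded chain carbon, cyano in place of acetyl gives a 2.2-fold higher number from compound 2 to compound 4 (0.33 log units; beyond the scatter), also modest and beyond the scatter, which shows that this substituent can shift the number with the rest of the structure held fixed, and nothing on hand accounts for any of these steps.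

The compounds shown leave open whether the step belongs to methoxy in particular or would also appear with another group on this aromatic carbon, such as hydroxyl, fluorine or an amine. They also leave open how the chain carbon would read with a carboxylic acid or a primary amide in place of cyano and acetyl.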